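Ethyl-to-butyl ester extension on the tert-butyl thioester

This account rests on a few compounds, and the source may have more. Where it says the series, first, only, none or still open, it means among the compounds named here.

Three members of this series have been read in an ADME assay on liver for metabolic stability, with liver carboxylesterase 1 (Homo sapiens) as the target; a higher number here means that the compound lasts longer, a lower number that the compound disappears faster. Compound 1 `CCOC(=O)[C@@H](N)CCC(=O)NCCSC(=O)c1ccccc1` gives 0.167 h in this assay. Compound 2 `CCCCOC(=O)[C@@H](N)CCC(=O)NCCSC(=O)c1ccccc1` gives 0.167 h, and compound 3 `CCOC(=O)[C@@H](N)CCC(=O)NCCSC(=O)C(C)(C)C` gives 0.167 h. Compound 3 thus stands level with compounds 1 and 2 at the digits reported: its nearest neighbour is compound 1, its furthest compound 2, and both gaps lie within the scatter. Two single-point steps are on record: no change at the digits printed from compound 1 to compound 2 (within the scatter) and no change at the digits printed from compound 1 to compound 3 (within the scatter).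

Compound 4 `CCCCOC(=O)[C@@H](N)CCC(=O)NCCSC(=O)C(C)(C)C` has not yet been measured. Relative to compound 3 the change is ethyl in place of hydrogen on a saturated chain carbon, two bonds along the chain from an oxygen next to a carbonyl group. The step that bears directly on this is no change at the digits printed from compound 1 to compound 2 (within the scatter), which is the same exchange carried out on the phenyl thioester of the shared core and produced nothing beyond the scatter. The other step, no change at the digits printed from compound 1 to compound 3 (within the scatter), shows that the thioester swap likewise left the half-life unmoved, so no hint of an interaction between the two sites is visible. The data rest on a single relevant pair, so the expectation is cautious but clear: no step beyond the scatter is expected, the estimated step being no change at the digits printed from compound 3 to compound 4 (within the scatter). Compound 4 is estimated at 0.167 h, with an expected range from 0.08 h to 0.35 h.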

Compound 4, half-life: 0.167 h
Beside the measured number, compound 4's estimate shows no gap at the digits printed, and the stated range covers the measured number.
By their numbers in this assay, from the lowest: compounds 1, 2, 3 and 4 (each within the scatter of the next).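

In this assay, ethyl in place of hydrogen at this position, on a saturated chain carbon, two bonds along the chain from an oxygen next to a carbonyl group, can now be read on a second core, with no change at the digits printed from compound 3 to compound 4 (within the scatter), and the two readings agree: the same change on two cores in this assay, no change at the digits printed (within the scatter) from compound 1 to compound 2 and no change at the digits printed (within the scatter) from compound 3 to compound 4, 1.0-fold (0.00 log units) apart, within the scatter of two such steps. The other change, tert-butyl in place of phenyl on a carbonyl carbon, can now also be read on a second core, with no change at the digits printed from compound 2 to compound 4 (within the scatter), and again the two readings agree: the same change on two cores in this assay, no change at the digits printed (within the scatter) from compound 1 to compound 3 and no change at the digits printed (within the scatter) from compound 2 to compound 4, 1.0-fold (0.00 log units) apart, within the scatter of two such steps. Compounds 1, 2, 3 and 4 thus close a square of two changes, and each change reads the same with either partner in place, so the two sites show no interaction at the digits printed.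

With all four compounds sharing one printed value, the series does not yet show any change to which this half-life responds. Still open, on these data alone, is whether a longer chain such as octyl in place of butyl, a carboxylic acid in place of the ethyl ester, or an amide in place of the thioester would separate from these four compounds.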